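From bromo to propyl at the assay limit

The source may hold more compounds than are shown below. What is called first, only, known or untested is meant among the compounds shown, and "the series" means these compounds.

Measured in a functional assay on HepG2 cells (Homo sapiens) for antiproliferative activity, read by CCK-8 assay, with a stated time of 72 h; on this read-out higher numbers stand for weaker inhibition and lower numbers for stronger inhibition:
- compound 1 `Nc1ccccc1NC(=O)c1ccc(COc2ccc(Br)cc2)cc1`: > 32000 nM, a limit of the assay
- compound 2 `Nc1ccccc1NC(=O)/C=C/c1ccc(COc2ccccc2)cc1`: > 32000 nM, a limit of the assay

Compound 1 yields no exact number in this assay, and its > 32000 nM is a limit rather than a measured value. Compound 2 also stands only at a limit, > 32000 nM. The record so far therefore consists of the limit of > 32000 nM in this assay, at which 2 of the 2 values shown sit.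

Compound 3 `CCCc1ccc(OCc2ccc(C(=O)Nc3ccccc3N)cc2)cc1`, not yet measured, keeps the core of compound 1 and changes one group: propyl in place of bromo on an aromatic carbon. Propyl takes the place of bromo on an aromatic carbon, para to a large group.

Within the data shown here, no step between measured compounds is available as a guide, so any forecast is tentative. In this assay, no step beyond the scatter is expected in either direction, and compound 3 is expected to remain close to the limit. This expectation starts from compound 1 with its limit of > 32000 nM. The expected step is a number no higher from compound 1 to compound 3 (the limit leaves the size open). The estimated value for compound 3 is 32000 nM, with an expected range from 10000 nM to 60000 nM.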

Compound 3, half-maximal inhibitory concentration: 4750 nM
For compound 3 the middle estimate is 6.7-fold (0.83 log units) above the measured one, and the stated range ends above it.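

In this assay, replacing bromo with propyl on an aromatic carbon, para to a large group, gives an at least 6.7-fold lower number from compound 1 to compound 3 (0.82 log units; beyond the scatter), so this one place on the shared core can bring a compound off the assay limit and to an exact number. Neither earlier compound showed this, and compound 1 stands at > 32000 nM, which is a limit of the assay and not a measured value. The step therefore marks only the least that the change from 4-bromophenyl to 4-propylphenyl can amount to, and its true size cannot be read, as most of the record still sits at that limit: the limit of > 32000 nM in this assay, at which 2 of the 3 values shown sit.

The compounds shown leave open whether the gain belongs to the propyl chain itself or only to the departure of bromo, and whether an ethyl group, a butyl chain or a methoxy group at the same place would lower the number further or return it to the limit. They also leave open whether propyl at this place would have a similar effect on the core of compound 2, which carries a different linker to its amide.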